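From isopropyl to dimethylaminoethyl on the chain carbon

This account rests on a few compounds, and the source may have more. Where it says the series, first, only, none or still open, it means among the compounds named here.

Compound 1 `CN(C(=O)/C=C/c1ccc(C(C)(C)C)cc1)c1ccc2c(c1)OCCO2`: > 4000 nM
Compound 2 `CC(C)C/C(=C\C(=O)Nc1ccc2c(c1)OCCO2)c1ccc(C(C)(C)C)cc1`: 16 nM

Of the compounds shown here, two have been tested in a functional assay on CHO cells for inhibition of transient receptor potential cation channel subfamily V member 1 (Homo sapiens); on this read-out higher numbers stand for weaker inhibition and lower numbers for stronger inhibition. For compound 1 the result is only a limit of the assay, > 4000 nM, as stated in the limit of > 4000 nM in this assay, at which 1 of the 2 values shown sits. Among the measured compounds shown here, compound 2 gives 16 nM in this assay, the only actual number among the two results. Compound 3 `CN(C)CCC/C(=C\C(=O)Nc1ccc2c(c1)OCCO2)c1ccc(C(C)(C)C)cc1` differs from compound 2 by 2-(dimethylamino)ethyl in place of isopropyl on a saturated chain carbon bound to a double-bonded chain carbon. For the measured compounds named here, no measured pair isolates a change of this kind, so the size of the step is uncertain. Compound 3 is expected to come out at 120 nM, within 25 nM to 900 nM. The estimated step of a 7.5-fold higher number from compound 2 to compound 3 (0.88 log units; beyond the scatter) is expected to be a weakening beyond the scatter.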

Compound 3, half-maximal inhibitory concentration: 3900 nM
The estimate for compound 3 lay 33-fold (1.51 log units) below the measured number; the whole stated range lies below it.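

In this assay, this place proves highly sensitive to what it carries: 2-(dimethylamino)ethyl in place of isopropyl on a saturated chain carbon bound to a double-bonded chain carbon gives a 240-fold higher number from compound 2 to compound 3 (2.39 log units; beyond the scatter). This single change takes compound 3 close to the top of the measurable range, where compound 1 stands at a limit of the assay: the limit of > 4000 nM in this assay, at which 1 of the 3 values shown sits.

From the compounds shown here alone, whether the loss follows from the nitrogen or from the longer chain stays open. An all-carbon pentyl chain and a shorter dimethylaminomethyl group at this place would separate the two.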